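Replacing 4-(methylsulfanyl)phenyl with 2-chlorophenyl in compound 4

This account rests on a few compounds, and the source may have more. Where it says the series, first, only, none or still open, it means among the compounds named here.

Going by the values given here, in a functional assay on A549 cells (Homo sapiens) for antiproliferative activity, read by MTT assay (on this read-out higher numbers stand for weaker inhibition and lower numbers for stronger inhibition), compound 3 `CSc1ccc(/C=N/Nc2ncc3c(n2)n(C2CCCC2)c(=O)c(=O)n3C)cc1` gives 14100 nM and holds the lowest number so far. Compound 1 `Cn1c(=O)c(=O)n(C2CCCC2)c2nc(N/N=C/c3cccc(Cl)c3Cl)ncc21` gives 39100 nM as its measured number. Compound 2 `COc1ccc(/C=N/Nc2ncc3c(n2)n(C2CCCC2)c(=O)c(=O)n3C)cc1` gives > 100000 nM as its result, and this is a limit of the assay and not a number.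

Compound 4 `Cn1c(=O)c(=O)n(C2CCCC2)c2nc(N/N=C/c3ccccc3Cl)ncc21` has 2-chlorophenyl in place of 4-(methylsulfanyl)phenyl on a carbon with a double bond to nitrogen, counted as 2-chlorophenyl in place of 4-(methylsulfanyl)phenyl on a carbon with a double bond to nitrogen in this change. The closest guide is a 2.8-fold lower number from compound 1 to compound 3 (0.44 log units; beyond the scatter) as the group changes from 2,3-dichlorophenyl to 4-(methylsulfanyl)phenyl. Changes at this place can be larger, as in an at least 7.0-fold lower number from compound 2 to compound 3 (0.85 log units; beyond the scatter) where the size rests on a limit. Among the compounds with values here, compound 1 is the only measured compound with chlorine on this phenyl ring, so returning to chlorine should give back much of that gain, though a single chlorine remains unmeasured.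

In this assay the estimated change is a 2.8-fold higher number from compound 3 to compound 4 (0.45 log units; beyond the scatter) and it points to a weaker result. The expected value for compound 4 is 40000 nM with an estimated range from 15000 nM to 100000 nM for repeated measurements.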

Compound 4, half-maximal inhibitory concentration: 9860 nM
The estimate for compound 4 lay 4.1-fold (0.61 log units) above the measured number; measured number below the stated range.
By their numbers in this assay, from the lowest: compounds 4 and 3 (each within the scatter of the next); then compound 1. At a limit, above all of these: compound 2.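

In this assay, hydrogen in place of one chlorine of the 2,3-dichlorophenyl group gives a real gain, a 4.0-fold lower number from compound 1 to compound 4 (0.60 log units; beyond the scatter), so among these compounds, a chlorine on this phenyl ring does not by itself go with a weaker result. The swap from 4-(methylsulfanyl)phenyl to 2-chlorophenyl gives a 1.4-fold lower number from compound 3 to compound 4 (0.16 log units; within the scatter), which means the two groups cannot be told apart here and sulfur is not required to reach this level of activity. The step of an at least 10-fold lower number from compound 2 to compound 4 (1.00 log units; beyond the scatter) starts from a limit of the assay and not a number: the limit of > 100000 nM in this assay, at which 1 of the 4 values shown sits.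

From the compounds shown here alone, whether 4-chlorophenyl would match 2-chlorophenyl remains open, so the placing of the chlorine cannot yet be judged. Going by these compounds, it is also open how an amine or a carboxylic acid on this phenyl ring would read out in this assay.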